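Difluorophenyl replacing trifluoromethylphenyl on a thienopyrimidine ether amide

The source may report more compounds than this note shows. Statements on the series, on what has been measured and on what is new or still open speak of the compounds shown alone.

Of the compounds shown here, three sharing one core have been measured in a functional assay on A549 cells (Homo sapiens) for cytotoxicity, read by MTT assay, with a stated time of 72 h; a lower number here means a stronger inhibitor, a higher number a weaker inhibitor. Compound 1 `Cc1cc(=O)n(-c2ccccc2C(F)(F)F)nc1C(=O)Nc1ccc(Oc2ncnc3ccsc23)cc1` gives 8850 nM. Within the data shown here, compound 2 `Cc1cc(=O)n(-c2ccc(F)cc2)nc1C(=O)Nc1ccc(Oc2ncnc3ccsc23)cc1` gives 2360 nM, and the change a 3.8-fold lower number from compound 1 to compound 2 (0.57 log units; beyond the scatter) is the only measured step on this side of the molecule. Compound 3 `Cc1cc(=O)n(-c2ccccc2C(F)(F)F)nc1C(=O)Nc1ccc(Oc2ncnc3sccc23)cc1` gives 19900 nM, the highest of the three numbers; it is separated from compound 1 by a 2.2-fold higher number from compound 1 to compound 3 (0.35 log units; beyond the scatter) and stands further still from compound 2, a gap beyond the scatter in both cases.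

Compound 4 `Cc1cc(=O)n(-c2ccc(F)c(F)c2)nc1C(=O)Nc1ccc(Oc2ncnc3sccc23)cc1` is not yet measured. It differs from compound 3 in one place: 3,4-difluorophenyl in place of 2-(trifluoromethyl)phenyl on an aromatic nitrogen. The step from compound 1 to compound 2 bears most directly on this change, since there too a fluorinated phenyl replaced the 2-(trifluoromethyl)phenyl on the aromatic nitrogen, and it lowered the number by a modest amount beyond the scatter. A 3,4-difluorophenyl is not the same group as a 4-fluorophenyl, so the expected step is read as similar in direction but less certain in size. The step of a 3.3-fold lower number from compound 3 to compound 4 (0.52 log units; beyond the scatter) is therefore expected to be a lowering in this assay, beyond the scatter. Compound 4 is estimated to give 6000 nM, with a range from 2500 nM to 15000 nM.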

Compound 4, half-maximal inhibitory concentration: 13500 nM
The estimate for compound 4 lay 2.3-fold (0.35 log units) below the measured number, and the stated range covers the measured number.
By their numbers in this assay, from the lowest: compound 2; then compounds 1, 4 and 3 (each within the scatter of the next, the first and the last beyond it).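

In this assay, putting 3,4-difluorophenyl in place of 2-(trifluoromethyl)phenyl on the aromatic nitrogen gives a step that lies within the scatter (a 1.5-fold lower number from compound 3 to compound 4 (0.17 log units; within the scatter)), so on the core of compound 3 this change does not separate the two compounds. The earlier replacement at this position, by 4-fluorophenyl on the core of compound 1, lay beyond the scatter (a 3.8-fold lower number from compound 1 to compound 2 (0.57 log units; beyond the scatter)), which shows that leaving behind the 2-(trifluoromethyl)phenyl does not by itself bring a step beyond the scatter in every case. The two steps differ both in the entering group and in the core that carries it, and nothing given here explains the contrast between them.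

As far as these compounds go, it remains open whether the contrast follows the second fluorine of the 3,4-difluorophenyl or the different core, a question that 4-fluorophenyl on the core of compound 3, or 3,4-difluorophenyl on the core of compound 1, would address. Also open, from the compounds shown here alone, is how this position would respond to a phenyl ring carrying a methoxy group or an amine, or to a group with no fluorine at all.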